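Nitro and Cyanosulfanyl Changes on a Shared Core

The source may hold more compounds than are shown below. What is called first, only, known or untested is meant among the compounds shown, and "the series" means these compounds.

Compound 1 `Clc1ccc(Cc2nn3c(Br)c(-c4ccccc4)nc3s2)cc1` carries a bromo group and a phenyl group on the shared core. In an ADME assay on CCRF-CEM cells (Homo sapiens) for cytotoxicity, with a stated time of 72 h (a higher number here means a weaker inhibitor, a lower number a stronger inhibitor), compound 1 gives only a limit, > 250000 nM, which is the limit of > 250000 nM in this assay, at which 1 of the 3 values shown sits. Compound 2 `O=[N+]([O-])c1ccc(-c2nc3sc(Cc4ccc(Cl)cc4)nn3c2Br)cc1` differs from compound 1 by nitro in place of hydrogen on an aromatic carbon; in this assay compound 2 gives 73000 nM, and an at least 3.4-fold lower number from compound 1 to compound 2 (0.53 log units; beyond the scatter). Compound 3 `N#CSc1c(-c2ccccc2)nc2sc(Cc3ccc(Cl)cc3)nn12` differs from compound 1 by cyanosulfanyl in place of bromo on an aromatic carbon; in this assay compound 3 gives 14000 nM, and an at least 17-fold lower number from compound 1 to compound 3 (1.25 log units; beyond the scatter). Compound 4 `N#CSc1c(-c2ccc([N+](=O)[O-])cc2)nc2sc(Cc3ccc(Cl)cc3)nn12` has not yet been measured and differs from compound 3 by nitro in place of hydrogen on an aromatic carbon, the same change as that from compound 1 to compound 2. Because an at least 3.4-fold lower number from compound 1 to compound 2 (0.53 log units; beyond the scatter), a step of similar size is expected here, though that earlier step is only a lower bound. The expected step is a 3.1-fold lower number from compound 3 to compound 4 (0.49 log units; beyond the scatter). Compound 4 is estimated at 4500 nM in this assay, with 1500 nM and 14000 nM as the expected range.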

Compound 4, half-maximal inhibitory concentration: 20000 nM
Compound 4: middle estimate off by 4.4-fold (0.65 log units), on the low side, outside the stated range (above it).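

In this assay, nitro in place of hydrogen on an aromatic carbon does not carry over from one core to the other, with a 1.4-fold higher number from compound 3 to compound 4 (0.15 log units; within the scatter), and the two steps differ: the same change on two cores in this assay, an at least 3.4-fold lower number (0.53 log units; beyond the scatter) from compound 1 to compound 2 and a 1.4-fold higher number (0.15 log units; within the scatter) from compound 3 to compound 4, at least 4.8-fold (0.68 log units) apart, beyond the scatter of two such steps. Cyanosulfanyl in place of bromo gives a lower number on both cores, with a 3.7-fold lower number from compound 2 to compound 4 (0.56 log units; beyond the scatter), but the size of the step does not carry over: the same change on two cores in this assay, an at least 17-fold lower number (1.25 log units; beyond the scatter) from compound 1 to compound 3 and a 3.7-fold lower number (0.56 log units; beyond the scatter) from compound 2 to compound 4, at least 4.8-fold (0.68 log units) apart, beyond the scatter of two such steps. Compound 1 gives only a limit, so the gaps between steps are bounds, and these compounds do not show why the steps differ: the limit of > 250000 nM in this assay, at which 1 of the 4 values shown sits.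

The compounds shown leave open how an amine or a carboxylic acid in place of nitro would behave on either core. As far as these compounds go, whether a longer chain in place of cyanosulfanyl would give a similar step also remains open.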